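From an Aryl Amide to an Aminoalkyl Amide

This account rests on a few compounds, and the source may have more. Where it says the series, first, only, none or still open, it means among the compounds named here.

Compound 1 `O=C(CCC(=O)OCCCCCCSc1ccc([N+](=O)[O-])c2nonc12)Nc1ccc(Br)cc1`: 4330 nM
Compound 2 `COc1ccc(NC(=O)CCC(=O)OCCCCCCSc2ccc([N+](=O)[O-])c3nonc23)cc1OC`: 4100 nM

In an ADME assay on L02 cells (Homo sapiens) for cytotoxicity, read by MTT assay, with a stated time of 72 h (a lower number here means a stronger inhibitor, a higher number a weaker inhibitor), compound 1 gives 4330 nM, the highest of the two numbers shown, while compound 2 gives 4100 nM; the step of a 1.1-fold lower number from compound 1 to compound 2 (0.02 log units; within the scatter) is within the scatter. Compound 3 `CN(C)CCNC(=O)CCC(=O)OCCCCCCSc1ccc([N+](=O)[O-])c2nonc12` differs from compound 1 as follows: 2-(dimethylamino)ethyl in place of 4-bromophenyl on an amide-type nitrogen. No measured step swaps an aromatic group on this amide-type nitrogen for a chain; the single step shown only tells that one change at the same place stayed within the scatter. The expected step is therefore a 1.4-fold higher number from compound 1 to compound 3 (0.14 log units; within the scatter), with a wide range. Compound 3 is estimated at 6000 nM, between 2500 nM and 15000 nM.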

Compound 3, half-maximal inhibitory concentration: 5980 nM
For compound 3 the middle estimate is 1.0-fold (0.00 log units) above the measured one; low and high end bracket the measured number.
By their numbers in this assay, from the lowest: compounds 2, 1 and 3 (each within the scatter of the next).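

In this assay, the step of a 1.4-fold higher number from compound 1 to compound 3 (0.14 log units; within the scatter) and the step of a 1.5-fold higher number from compound 2 to compound 3 (0.16 log units; within the scatter) both stay within the scatter. On this amide-type nitrogen, then, 2-(dimethylamino)ethyl, which has no ring, stands level with 4-bromophenyl and 3,4-dimethoxyphenyl, whereas the earlier pair compared only groups with an aromatic ring. Nothing available explains this result. The compounds shown leave open whether a longer chain ending in the same dimethylamino group, or a chain ending in a carboxylic acid, would also stay within the scatter.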